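The compounds below may be only part of what the source reports. "The series", "measured", "known", "first", "only" and "open" are said of these compounds alone.

Working notes on the series in an assay on cells for inhibition of Voltage-dependent T-type calcium channel subunit alpha-1H (Homo sapiens), read by patch clamp, tested at 10 uM; on this read-out lower numbers stand for less inhibition and higher numbers for more inhibition at the one concentration tested (going by the name of the read-out).

Within the data shown here, compound 1 `CCOC(=O)C1=C(C)NC(=O)N(CCC(=O)NNS(=O)(=O)c2ccccc2)C1c1cccc([N+](=O)[O-])c1` is the one member with a number: in this assay compound 1 gives 50%. Among the measured compounds shown here, compound 2 `CCOC(=O)C1=C(C)NC(=O)N(CCC(=O)n2nc(C)cc2C)C1c1cccc([N+](=O)[O-])c1` carries the same core, and in this assay compound 2 is reported as "not active" (no number reported), with no figure attached, so it stands on no single number and no measured step can be drawn between it and compound 1.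

Compound 3 `CCOC(=O)C1=C(C)NC(=O)N(CCC(=O)NNC(=S)Nc2ccccc2)C1c1cccc([N+](=O)[O-])c1` is not yet measured. Against compound 2 the change is a group of 11 heavy atoms (7 carbon, 3 nitrogen, 1 sulfur; one six-membered aromatic ring of carbon only) in place of a group of 7 heavy atoms (5 carbon, 2 nitrogen; one five-membered aromatic ring with 2 hetero atoms), on a carbonyl carbon. For the measured compounds named here, no measured pair frames this change, so its expected size rests only on compound 1 and compound 2: compound 1 at 50% sets the upper mark seen so far, and compound 2 the lower one with no number. The step from compound 2 to compound 3 is expected to go upward in this assay, by more than the scatter, though with wide uncertainty. Compound 3 is accordingly estimated at 35%, with a range from 10% to 60%.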

Compound 3, a percentage reported as inhibition, at one concentration (the size of the read-out at that concentration, not a potency): "not active" (no number reported)
Compound 3 has no reported number here; the estimate stays without a comparison.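

In this assay compound 3, like compound 2, carries no number, so no step can be read from compound 2 to compound 3. The compounds shown leave open how much inhibition, if any, either gives. No supporting evidence bears on this result.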